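Thioether aryl swap on the propenamide-bearing compound 1

A few compounds are considered here, and "the series" means these few. Any claim that something is new, unique, unknown or untested is made for them only; others in the source may bear on it.

Compound 1 `Cc1cc(C)cc(SCc2ccc(/C=C/C(=O)Nc3ccccc3N)cc2)c1` gives 8.61% in a functional assay on SMMC-7721 cells (Homo sapiens) for inhibition, read by CCK-8 assay, with a stated time of 72 h, tested at 2 uM (on this read-out higher numbers stand for more inhibition of growth at the one concentration tested and lower numbers for less inhibition of growth), the lowest of the three numbers in hand. Compound 2 `Cc1ccc(SCc2ccc(C(=O)Nc3ccccc3N)cc2)cc1` gives 25.1% and compound 3 `CC(C)(C)c1ccc(SCc2ccc(C(=O)Nc3ccccc3N)cc2)cc1` gives 23.6%; both share a shorter core than compound 1 and both stand beyond the scatter above it. The change to compound 4 `CC(C)(C)c1ccc(SCc2ccc(/C=C/C(=O)Nc3ccccc3N)cc2)cc1` is 4-(tert-butyl)phenyl in place of 3,5-dimethylphenyl on a sulfur. Among the measured compounds shown here, the only measured step touching the same region is a number 1.5 percentage points lower from compound 2 to compound 3 (within the scatter), which lies within the scatter; it exchanges methyl for tert-butyl on the core shared by compound 2 and compound 3, not on the core of compound 1, and it does not remove a second methyl. For the measured compounds named here, no measured pair sets 3,5-dimethylphenyl against 4-(tert-butyl)phenyl on the core of compound 1. The step from compound 1 to compound 4 is therefore expected to be small, a number 2.4 percentage points higher from compound 1 to compound 4 (within the scatter), given that the step from compound 2 to compound 3 did not move beyond the scatter. Compound 4 is estimated at 11%, within 2% to 24%.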

Compound 4, percent growth inhibition at one concentration: 18.3%
Beside the measured number, compound 4's estimate is 7.3 percentage points below it; the range from low to high includes it.
By their numbers in this assay, from the lowest: compounds 1, 4, 3 and 2 (each within the scatter of the next, the first and the last beyond it).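

On the longer core, in this assay the swap of 3,5-dimethylphenyl for 4-(tert-butyl)phenyl on a sulfur gives a number 9.7 percentage points higher from compound 1 to compound 4 (within the scatter) and so leaves the two groups unseparated at this position. With 4-(tert-butyl)phenyl held fixed, compound 3 at 23.6% and compound 4 at 18.3% lie within the scatter of each other, so this pair does not separate the two cores either. Nothing at hand bears on what lies behind these numbers.

From the compounds shown here alone, whether a phenyl on the sulfur carrying an amine or a carboxylic acid, or a longer chain in place of tert-butyl, would give a step beyond the scatter stays open. Going by these compounds, the read-out covers a single concentration, so how these compounds compare at other concentrations also stays open.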